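A Bromine Shift from 3-Bromophenyl to 4-Bromophenyl

A few compounds are considered here, and "the series" means these few. Any claim that something is new, unique, unknown or untested is made for them only; others in the source may bear on it.

In a functional assay on A549 cells (Homo sapiens) for antiproliferative activity, read by MTT assay, with a stated time of 48 h (a lower number here means a stronger inhibitor, a higher number a weaker inhibitor), compound 1 (`COc1ccc(-c2nc3cccc(-c4cc(OC)c(OC)c(OC)c4)c3o2)cc1OC`) gives 2800 nM and compound 2 (`COc1cc(-c2cccc3nc(-c4cccc(Br)c4)oc23)cc(OC)c1OC`) gives 2100 nM as measured numbers. Going by the values given here, these are the only two numbers so far, and they lie within the scatter of each other, so compound 2 stands level with compound 1. Compound 3 (`COc1cc(-c2cccc3nc(-c4ccc(Br)cc4)oc23)cc(OC)c1OC`) has not yet been measured. It differs from compound 2 as follows: 4-bromophenyl in place of 3-bromophenyl on an aromatic carbon and the two have the same atoms, joined differently. The 4-bromophenyl replaces the 3-bromophenyl on an aromatic carbon of the five-membered aromatic ring, next to the ring nitrogen and next to the ring oxygen.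

Among the compounds with values here, only one measured step bears on this change. The step of a 1.3-fold lower number from compound 1 to compound 2 (0.12 log units; within the scatter) exchanged the group on that same carbon and stayed within the scatter. Within the data shown here, no measured pair shows the bromine changing place alone, so the evidence is thin, and no step beyond the scatter is expected in either direction. The expected change is a 1.0-fold higher number from compound 2 to compound 3 (0.02 log units; within the scatter) and it would not stand out from the scatter. Compound 3 is estimated at 2200 nM in this assay with an expected range of 900 nM to 5000 nM for its measurement.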

Compound 3, half-maximal inhibitory concentration: > 25000 nM
Compound 3: only a limit was reported (the forecaster's own chance of this, stated with the estimate: 5%); at least 11-fold (1.05 log units) between middle value and limit.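

In this assay compound 3 gives > 25000 nM, which is a limit and not a number: the limit of > 25000 nM in this assay, at which 1 of the 3 values shown sits.

The result shows that this carbon of the five-membered aromatic ring is not indifferent to the arrangement of the phenyl group it carries: with the same atoms joined differently, the shift of the bromine gives an at least 11-fold higher number from compound 2 to compound 3 (1.07 log units; beyond the scatter), whereas the earlier exchange of groups on this carbon gave only a 1.3-fold lower number from compound 1 to compound 2 (0.12 log units; within the scatter). The 4-bromophenyl group also stands apart from the 3,4-dimethoxyphenyl group, with an at least 8.9-fold higher number from compound 1 to compound 3 (0.95 log units; beyond the scatter), so among the three groups shown here, 4-bromophenyl alone is separated from the others, while 3-bromophenyl and 3,4-dimethoxyphenyl remain level.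

The compounds shown leave open whether this loss belongs to bromine itself or to any group placed as it is in 4-bromophenyl, since chlorine, an amine or a carboxylic acid in place of the bromine could follow either 3-bromophenyl or 4-bromophenyl. On these data alone, they also leave open how far the true value of compound 3 lies beyond its limit, and so the full size of the step remains unknown.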